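From Compound 3 to Compound 4: A Nitrophenyl Exchange

The compounds below may be only part of what the source reports. "The series", "measured", "known", "first", "only" and "open" are said of these compounds alone.

In a functional assay on HeLa cells (Homo sapiens) for cytotoxicity, read by MTT assay, with a stated time of 72 h (a lower number here means a stronger inhibitor, a higher number a weaker inhibitor), compound 1 `COc1cc(/C=C/C(=O)Nc2cc3c(Nc4ccc(F)c(Cl)c4)ncnc3cc2O[C@H]2CCOC2)cc(OC)c1OC` gives 24500 nM and compound 3 `COc1ccc(/C=C/C(=O)Nc2cc3c(Nc4ccc(F)c(Cl)c4)ncnc3cc2O[C@H]2CCOC2)c(OC)c1OC` gives 4830 nM. Among the compounds with values here, compound 3 therefore holds the lower of the only two numbers available. A further relative, compound 2 `COc1cc2ncnc(Nc3ccc(F)c(Cl)c3)c2cc1NC(=O)/C=C/c1ccccc1[N+](=O)[O-]`, carries the 2-nitrophenyl group but offers no number, its result standing as "not determined" (no result reported). Compound 4 `O=C(/C=C/c1ccccc1[N+](=O)[O-])Nc1cc2c(Nc3ccc(F)c(Cl)c3)ncnc2cc1O[C@H]1CCOC1` keeps the rest of compound 3 and changes one group: 2-nitrophenyl in place of 2,3,4-trimethoxyphenyl on a double-bonded chain carbon bound to a double-bonded chain carbon. Within the data shown here, with no result from compound 2, the entering group has no measured precedent here.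

Among the measured compounds shown here, only one measured step bears on the change, a 5.1-fold lower number from compound 1 to compound 3 (0.71 log units; beyond the scatter). That step is modest but beyond the scatter, and it involves only an exchange between two trimethoxyphenyl patterns. It shows that the number in this assay can shift with the group at this place, but it gives no direction for a nitrophenyl group. Since compound 3 at 4830 nM sits at the low end of this small set, a modest move towards a higher number is expected, though with wide uncertainty. The expected change is a 1.9-fold higher number from compound 3 to compound 4 (0.27 log units; within the scatter). For compound 4 the estimated value is 9000 nM, with an expected range from 2500 nM to 30000 nM.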

Compound 4, half-maximal inhibitory concentration: 29600 nM
Beside the measured number, compound 4's estimate is 3.3-fold (0.52 log units) below it, and the stated range covers the measured number.
By their numbers in this assay, from the lowest: compound 3; then compounds 1 and 4 (each within the scatter of the next).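

In this assay, the exchange at this place, on a double-bonded chain carbon bound to a double-bonded chain carbon, gives the first measured result for a 2-nitrophenyl group: a 6.1-fold higher number from compound 3 to compound 4 (0.79 log units; beyond the scatter) when it replaces 2,3,4-trimethoxyphenyl, so the lower number seen with that trimethoxyphenyl pattern does not carry over to the smaller entering group. Set against 3,4,5-trimethoxyphenyl, the same group gives a 1.2-fold higher number from compound 1 to compound 4 (0.08 log units; within the scatter), so these two groups cannot be told apart here, and among the three groups with numbers only 2,3,4-trimethoxyphenyl stands apart, with both of its steps beyond the scatter. No measurement shown offers a reason for these differences.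

Steps involving compound 2 cannot be read, as it has no reported result, so the 2-nitrophenyl group cannot be followed on a second background. As far as these compounds go, it also remains open whether the higher number with this group reflects the nitro group itself or the absence of the methoxy groups, and whether an amine or a single methoxy group on the same phenyl ring would return the number towards the lower value.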